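The source may report more compounds than this note shows. Statements on the series, on what has been measured and on what is new or still open speak of the compounds shown alone.

Working notes on the series. Compound 1 `O=C1C(Nc2ccccc2F)=CC(=O)c2c1nc1n2[C@H]2OC[C@@H](O)[C@H]2OC1` carries 2-fluorophenyl on an amine nitrogen of the shared core. In a functional assay on MCF7 cells (Homo sapiens) for inhibition, read by sulforhodamine B assay (on this read-out higher numbers stand for weaker inhibition and lower numbers for stronger inhibition), compound 1 gives > 4000 nM, which is a limit and not a number. Compound 2 `O=C1C=C(NC2CCCCC2)C(=O)c2c1nc1n2[C@H]2OC[C@@H](O)[C@H]2OC1`, with cyclohexyl on that nitrogen, gives > 8000 nM, also a limit. Among the measured compounds shown here, compound 3 `CCc1ccc(NC2=CC(=O)c3nc4n(c3C2=O)[C@H]2OC[C@@H](O)[C@H]2OC4)cc1`, with 4-ethylphenyl there, gives 960 nM as the only true number so far.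

Compound 4 `O=C1C(Nc2ccc(C(F)(F)F)cc2)=CC(=O)c2c1nc1n2[C@H]2OC[C@@H](O)[C@H]2OC1` differs from compound 1 as follows: 4-(trifluoromethyl)phenyl in place of 2-fluorophenyl on an amine nitrogen. In short, 4-(trifluoromethyl)phenyl replaces 2-fluorophenyl on an amine nitrogen.

For the measured compounds named here, one measured step bears on this change, an at least 8.3-fold lower number from compound 2 to compound 3 (0.92 log units; beyond the scatter), and it lies beyond the scatter. It starts from the limit of > 8000 nM in this assay, at which 1 of the 3 values shown sits, so its size is only a bound. It is also a different exchange on that nitrogen, so it offers guidance and no direct measure. The expectation rests mainly on compound 3 at 960 nM, the closest match to compound 4 in carrying a substituted phenyl group named with the same 4-position. A lower number than the limit of compound 1 is therefore expected, though compound 4 may itself return only a limit. The expected change is an at least 2.6-fold lower number from compound 1 to compound 4 (0.42 log units; beyond the scatter) in this assay. For compound 4 the estimated value is 1500 nM, with an expected range from 500 nM to 5000 nM.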

Compound 4, half-maximal inhibitory concentration: > 4000 nM
Compound 4 was reported as a limit; the forecaster's own chance of this, stated with the estimate: 20%; middle value at least 2.6-fold (0.42 log units) from the limit.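

Compound 4 returns a limit, as compound 1 does, so no step between the two can be read in this assay: the limit of > 4000 nM in this assay, at which 2 of the 4 values shown sit.

As far as these compounds go, what remains open is how far 4-(trifluoromethyl)phenyl and 2-fluorophenyl on that amine nitrogen actually differ, and where either stands relative to compound 3 at 960 nM.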